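Phenol Analogue of a Quinolone Ester in Liver-Cell Cytotoxicity

This account rests on a few compounds, and the source may have more. Where it says the series, first, only, none or still open, it means among the compounds named here.

Compound 1 `CCOC(=O)c1c(-c2cccc(OC(C)C)c2)[nH]c2cc(OC)ccc2c1=O` was examined in an ADME assay on HepG2 cells (Homo sapiens) for cytotoxicity, read by luminescence, with a stated time of 72 h; on this read-out higher numbers stand for an effect only at larger amounts of compound and lower numbers for an effect already at smaller amounts. In this assay compound 1 gives > 21500 nM, which is a limit of the assay and not a number. Compound 2 `CCOC(=O)c1c(-c2cccc(C(C)=O)c2)[nH]c2cc(OC)ccc2c1=O` carries an acetyl in place of the isopropoxy on the aromatic carbon; in this assay compound 2 gives > 21500 nM, again a limit. Compound 3 `CCOC(=O)c1c(-c2cccc(N(C)C)c2)[nH]c2cc(OC)ccc2c1=O` carries a dimethylamino on that aromatic carbon; in this assay compound 3 gives > 21500 nM, also a limit. The steps a step that the two limits leave unreadable from compound 1 to compound 2 and a step that the two limits leave unreadable from compound 1 to compound 3, as well as a step that the two limits leave unreadable from compound 2 to compound 3, cannot be sized because of the limit of > 21500 nM in this assay, at which 3 of the 3 values shown sit.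

Compound 4 `CCOC(=O)c1c(-c2cccc(O)c2)[nH]c2cc(OC)ccc2c1=O` is the next member of the series: hydrogen in place of isopropyl on an oxygen on an aromatic ring. None of the measured steps yields a readable size, and all three shown values sit at the same limit, so no direction of change can be drawn from them. For compound 4 the expected step in this assay is a step that the limit leaves unreadable from compound 1 to compound 4, nothing beyond the scatter. Compound 4 is therefore estimated at 30000 nM, between 12000 nM and 90000 nM, and is expected most likely to be reported once more only as a limit.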

Compound 4, half-maximal effective concentration: > 21500 nM
Compound 4 ended at the assay's limit (the forecaster's own chance of this, stated with the estimate: 85%); the middle value lies beyond the limit too.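

No step from compound 1, compound 2 or compound 3 to compound 4 can be read in this assay, because all four compounds stand at the same limit of the assay: the limit of > 21500 nM in this assay, at which 4 of the 4 values shown sit.

The compounds shown leave open at what concentration any of the four would reach a half-maximal effect, and whether the isopropoxy, acetyl, dimethylamino and hydroxy compounds differ at all in this assay.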